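From 2-fluorophenyl to 3,4,5-trimethoxyphenyl on a shared core

The source may hold more compounds than are shown below. What is called first, only, known or untested is meant among the compounds shown, and "the series" means these compounds.

Of the compounds shown here, two built on a shared core have been measured in a functional assay on QGY-7703 cells (Homo sapiens) for cytotoxicity, read by MTT assay, with a stated time of 24 h; on this read-out higher numbers stand for weaker inhibition and lower numbers for stronger inhibition. Compound 1 (`COc1cc(/C=C2\CN(S(=O)(=O)c3ccc(F)cc3)C/C(=C\c3cc(OC)c(OC)c(OC)c3)C2=O)cc(OC)c1OC`) gives 2220 nM. Compound 2 (`COc1cc(/C=C2\CN(S(=O)(=O)c3ccc(F)cc3)C/C(=C\c3ccccc3F)C2=O)cc(OC)c1`) gives 14000 nM, the higher of the two numbers and thus the weaker inhibition, and its gap to compound 1 lies beyond the scatter.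

Compound 3 (`COc1cc(/C=C2\CN(S(=O)(=O)c3ccc(F)cc3)C/C(=C\c3cc(OC)c(OC)c(OC)c3)C2=O)cc(OC)c1`) has not yet been measured. It departs from compound 2 in one place: 3,4,5-trimethoxyphenyl in place of 2-fluorophenyl on a double-bonded chain carbon bound to a double-bonded ring carbon. In words, this is 3,4,5-trimethoxyphenyl in place of 2-fluorophenyl on a double-bonded chain carbon bound to a double-bonded ring carbon. For the measured compounds named here, no measured pair isolates this change, so its size cannot be read directly from the data. Compound 1 also carries 3,4,5-trimethoxyphenyl at such a carbon and stands at 2220 nM, which points to a lower number for the new compound. The expected change is a 3.5-fold lower number from compound 2 to compound 3 (0.54 log units; beyond the scatter), towards stronger inhibition and beyond the scatter. Compound 3 is estimated at 4000 nM, with an expected range of 1500 nM to 10000 nM.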

Compound 3, half-maximal inhibitory concentration: 5200 nM
Compound 3: middle estimate off by 1.3-fold (0.11 log units), on the low side; the measured number falls inside the stated range.
By their numbers in this assay, from the lowest: compound 1; then compound 3; then compound 2.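

Replacing 2-fluorophenyl with 3,4,5-trimethoxyphenyl on a double-bonded chain carbon bound to a double-bonded ring carbon can now be read on its own in this assay, and it gives a modest gain in inhibition (a 2.7-fold lower number from compound 2 to compound 3 (0.43 log units; beyond the scatter)), so this position responds to the choice of aromatic group even with the rest of the molecule held fixed. The second pair isolates a different change, hydrogen in place of methoxy on an aromatic carbon, which costs a similarly modest amount of inhibition (a 2.3-fold higher number from compound 1 to compound 3 (0.37 log units; beyond the scatter)), so the methoxy group present in compound 1 and absent from compound 3 also counts, and neither single change accounts for the full spread among the three compounds. Nothing available on these compounds explains why either change has the effect it does.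

As far as these compounds go, whether an aminomethyl or a carboxylic acid on the aromatic ring at this carbon would push the number lower or higher remains open. From the compounds shown here alone, it is also open whether the two steps would keep their size with a group other than 4-fluorophenylsulfonyl on the shared core.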